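This account rests on a few compounds, and the source may have more. Where it says the series, first, only, none or still open, it means among the compounds named here.

Measured so far in an ADME assay on L6 cells (Rattus norvegicus) for cytotoxicity, read by resazurin assay, with a stated time of 72 h (a lower number here means a stronger inhibitor, a higher number a weaker inhibitor), with these values:
Compound 1 `CN(C)C12CC(c3ccccc3)C(CN(C(=O)CN3CCCCC3)C1)C(c1ccccc1)C2` gives 12100 nM
Compound 2 `CN1CCN(CCC(=O)N2CC3C(c4ccccc4)CC(N(C)C)(CC3c3ccccc3)C2)CC1` gives 13000 nM

Compound 2 at 13000 nM lies within the scatter of compound 1 at 12100 nM and the pair cannot be ordered. Compound 3 `CN(C)C12CC(c3ccccc3)C(CN(C(=O)CCN3CCCC3)C1)C(c1ccccc1)C2` has not been measured yet. It differs from compound 2 by pyrrolidin-1-yl in place of 4-methylpiperazin-1-yl on a saturated chain carbon, two bonds along the chain from a carbonyl carbon and the rest of the structure stays the same. Within the data shown here, the single measured step is a 1.1-fold higher number from compound 1 to compound 2 (0.03 log units; within the scatter) and it is the only evidence on exchanging one of these groups for another. Among the measured compounds shown here, no measured compound carries pyrrolidin-1-yl, so the support is thin. With that one step as the guide, no change beyond the scatter is expected in this assay and no direction is favoured. The estimated change is a 1.1-fold lower number from compound 2 to compound 3 (0.03 log units; within the scatter) and it should be read as no real shift. For compound 3 the estimated value is 12000 nM with an expected range from 5500 nM to 28000 nM in this assay.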

Compound 3, half-maximal inhibitory concentration: 11700 nM
Beside the measured number, compound 3's estimate is 1.0-fold (0.01 log units) above it; the range from low to high includes it.
By their numbers in this assay, from the lowest: compounds 3, 1 and 2 (each within the scatter of the next).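

In this assay, among these compounds, pyrrolidin-1-yl in place of 4-methylpiperazin-1-yl on a saturated chain carbon, two bonds along the chain from a carbonyl carbon, gives a 1.1-fold lower number from compound 2 to compound 3 (0.05 log units; within the scatter) and so stays within the scatter, as the first exchange at this end of the molecule did. The other comparison, (pyrrolidin-1-yl)methyl in place of piperidin-1-yl on a saturated chain carbon bound to a carbonyl carbon, gives a 1.0-fold lower number from compound 1 to compound 3 (0.01 log units; within the scatter) and also stays within the scatter. A five-membered non-aromatic ring with 1 hetero atom therefore reads the same here as the six-membered rings of compound 1 and compound 2, so neither ring size nor the second ring nitrogen separates these three compounds, and no measurement on hand speaks to the reason for this flat picture.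

Still open, from the compounds shown here alone, is whether a terminal group without a ring, such as an open-chain dimethylamino group, or one without a basic nitrogen, such as a carboxylic acid, would leave the scatter at this position. Also open, going by these compounds, is whether a longer chain between the carbonyl and the terminal amine would read any differently in this assay on the shared core.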